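Three Ureas Measured, a Fourth Awaiting Its Number

A few compounds are considered here, and "the series" means these few. Any claim that something is new, unique, unknown or untested is made for them only; others in the source may bear on it.

All three measured compounds share one core, a urea linking an aryl group to a cyclohexyl ring that carries an aryl ether, and were tested in a functional assay on CRL2813 cells (Homo sapiens) for cytotoxicity, read by sulforhodamine B assay, with a stated time of 5 days; on this read-out lower numbers stand for stronger inhibition and higher numbers for weaker inhibition.

Compound 1, `O=C(Nc1cccc(C(F)(F)F)c1)N[C@H]1CC[C@H](Oc2cccc(C(F)(F)F)c2)CC1`, gives 1300 nM.
Compound 2, `O=C(Nc1cccc(C(F)(F)F)c1)N[C@H]1CC[C@H](Oc2ccc(C(F)(F)F)cc2)CC1`, gives 460 nM.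
Compound 3, `CSc1ccccc1NC(=O)N[C@H]1CC[C@H](Oc2ccc(F)cc2)CC1`, gives > 20000 nM, which is a limit of the assay and not a number.

Within this small set, the only single-point step is a 2.8-fold lower number from compound 1 to compound 2 (0.45 log units; beyond the scatter), and it changes the aryl ether side of the core. Compound 3 stands apart: its result is a limit, and (the limit of > 20000 nM in this assay, at which 1 of the 3 values shown sits), so it can only be said that compound 3 falls beyond what this assay resolves.

Compound 4, `Cc1cccc(NC(=O)N[C@H]2CC[C@H](Oc3ccc(F)cc3)CC2)c1`, differs from compound 3 in one place: 3-methylphenyl in place of 2-(methylsulfanyl)phenyl on an amide-type nitrogen. Within the data shown here, no measured step touches the amide nitrogen, so none bears directly on this change. The aryl on that nitrogen in compounds 1 and 2 is 3-(trifluoromethyl)phenyl, and 3-methylphenyl resembles that arrangement more than 2-(methylsulfanyl)phenyl does. On that basis compound 4 is expected to give a measurable number, estimated at 8000 nM with a range from 1500 nM to 40000 nM. The step this estimate implies, an at least 2.5-fold lower number from compound 3 to compound 4 (0.39 log units; beyond the scatter), remains an expectation until compound 4 is measured.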

Compound 4, half-maximal inhibitory concentration: 14400 nM
The estimate for compound 4 lay 1.8-fold (0.26 log units) below the measured number; measured number inside the range.
By their numbers in this assay, from the lowest: compound 2; then compound 1; then compound 4. At a limit, above all of these: compound 3.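

Among these compounds, changing the group on the amide-type nitrogen from 2-(methylsulfanyl)phenyl to 3-methylphenyl, with the rest of the structure held fixed, gives the first real number for this pair: in this assay compound 4 gives 14400 nM. The result for compound 3 remains a limit of the assay and not a number: the limit of > 20000 nM in this assay, at which 1 of the 4 values shown sits.

The change can be read only as an at least 1.3-fold lower number from compound 3 to compound 4 (0.14 log units; that floor lies within the scatter); the true gap could be larger, but these values alone do not establish a difference beyond ordinary repeat variation.

The compounds shown do not separate the identity of the methylsulfanyl group from its place on the ring, and they leave open how 3-(trifluoromethyl)phenyl would read on this nitrogen with the rest of compound 4 unchanged. From the compounds shown here alone, what an aryl group carrying an amine or a carboxylic acid in place of the methyl would give in this assay also stays open.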